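Chain-end amines on a shared core: compound 4

The source may hold more compounds than are shown below. What is called first, only, known or untested is meant among the compounds shown, and "the series" means these compounds.

The measured compounds:
Compound 1, `CCCCCCOc1c(-c2cc(OC)c(OC)c(OC)c2)oc2ccccc2c1=O`: 19600 nM
Compound 2, `CCCN(CCC)CCCOc1c(-c2cc(OC)c(OC)c(OC)c2)oc2ccccc2c1=O`: 17900 nM
Compound 3, `CCCN(CCC)CCCCOc1c(-c2cc(OC)c(OC)c(OC)c2)oc2ccccc2c1=O`: 16800 nM

In a functional assay on LNCaP cells (Homo sapiens) for antiproliferative activity, read by WST assay, with a stated time of 3 days (a higher number here means a weaker inhibitor, a lower number a stronger inhibitor), compound 1 gives 19600 nM, the highest of the three numbers. The nearest neighbour lies a 1.1-fold lower number from compound 1 to compound 2 (0.04 log units; within the scatter), the furthest a 1.2-fold lower number from compound 1 to compound 3 (0.07 log units; within the scatter). Between the two amine-bearing compounds the gap is just as small, a 1.1-fold lower number from compound 2 to compound 3 (0.03 log units; within the scatter). All three numbers therefore sit within the scatter of one another, and no order among them can be read from the data.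

Compound 4, `CCCCN(CCCC)CCCCOc1c(-c2cc(OC)c(OC)c(OC)c2)oc2ccccc2c1=O`, differs from compound 1 in one place:
dibutylamino in place of ethyl on a saturated chain carbon, four bonds along the chain from an oxygen on an aromatic ring

Within the data shown here, the step that bears most directly on this change is the one from compound 1 to compound 3, where a dipropylamino group entered at the same saturated chain carbon, four bonds along the chain from an oxygen on an aromatic ring, and moved the number only a 1.2-fold lower number from compound 1 to compound 3 (0.07 log units; within the scatter). The neighbouring exchanges, a 1.1-fold lower number from compound 1 to compound 2 (0.04 log units; within the scatter) and a 1.1-fold lower number from compound 2 to compound 3 (0.03 log units; within the scatter), were equally small. Lengthening both alkyl arms of the amine by one carbon has no measured precedent here, so the expectation rests on these three steps alone: compound 4 is expected to give 16000 nM, within 8000 nM to 32000 nM, a step of a 1.2-fold lower number from compound 1 to compound 4 (0.09 log units; within the scatter) that is not expected to reach beyond the scatter.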

Compound 4, half-maximal inhibitory concentration: 7800 nM
Compound 4: middle estimate off by 2.1-fold (0.31 log units), on the high side, and the stated range ends above it.
By their numbers in this assay, from the lowest: compound 4; then compounds 3, 2 and 1 (each within the scatter of the next).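

Among these compounds, at this saturated chain carbon, four bonds along the chain from an oxygen on an aromatic ring, dibutylamino produced the first change in this assay to lie beyond the scatter, with a 2.5-fold lower number from compound 1 to compound 4 (0.40 log units; beyond the scatter) as a modest step, whereas dipropylamino at the same place had stayed within it. The amine's alkyl arms therefore matter here, at least in this one exchange: dibutylamino in place of dipropylamino gives a 2.2-fold lower number from compound 3 to compound 4 (0.33 log units; beyond the scatter) on the same chain, and the comparison with the shorter-chain amine gives a 2.3-fold lower number from compound 2 to compound 4 (0.36 log units; beyond the scatter) as a step of similar size, though that step changes both the chain and the arms. Nothing measured among these compounds accounts for the lower number.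

From the compounds shown here alone, the result rests on compound 4 alone, so it remains open whether the number would keep falling with longer arms such as dipentylamino, or whether a ring amine such as piperidine would do the same at this place. Going by these compounds, it is also open whether dibutylamino would give a similar number on the shorter chain of compound 2, which would separate the effect of the arms from that of the chain.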